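This account rests on a few compounds, and the source may have more. Where it says the series, first, only, none or still open, it means among the compounds named here.

Compound 1 `CCOC(=O)/C=C/c1ccc2c(c1)C(=O)C(=O)N2Cc1ccc(OC)cc1`: 30 nM
Compound 2 `CCCCOC(=O)/C=C/c1ccc2c(c1)C(=O)C(=O)N2Cc1ccc(OC)cc1`: 220 nM

In a functional assay on Jurkat cells (Homo sapiens) for antiproliferative activity, read by MTT assay, with a stated time of 48 h (a higher number here means a weaker inhibitor, a lower number a stronger inhibitor), compound 2, at 220 nM, has the higher of the two numbers, so it is the weaker inhibitor. Compound 3 `COc1ccc(CN2C(=O)C(=O)c3cc(/C=C/C(=O)OCCO)ccc32)cc1` puts hydroxy in place of ethyl on a saturated chain carbon, two bonds along the chain from an oxygen next to a carbonyl group, turning butyl into 2-hydroxyethyl: hydroxy in place of ethyl on a saturated chain carbon, two bonds along the chain from an oxygen next to a carbonyl group. Among the measured compounds shown here, one measured step bears on this place: ethyl replacing hydrogen there gave a 7.3-fold higher number from compound 1 to compound 2 (0.87 log units; beyond the scatter). Neither measured compound carries hydroxy, so that step is only a rough guide. A somewhat smaller change in the opposite direction is expected, estimated as a 3.1-fold lower number from compound 2 to compound 3 (0.50 log units; beyond the scatter). The expected value for compound 3 is 70 nM, with an estimated range of 20 nM to 250 nM.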

Compound 3, half-maximal inhibitory concentration: 500 nM
Estimate against measurement, compound 3: 7.1-fold (0.85 log units) below, and the stated range ends below it.
By their numbers in this assay, from the lowest: compound 1; then compound 2; then compound 3.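

Hydroxy in place of ethyl did not win back the lost activity in this assay but gave a 2.3-fold higher number from compound 2 to compound 3 (0.36 log units; beyond the scatter), and hydroxy in place of hydrogen gave a 17-fold higher number from compound 1 to compound 3 (1.22 log units; beyond the scatter). At this saturated chain carbon, then, both replacements of hydrogen raise the number, hydroxy more than ethyl, and compound 1 remains the strongest of the three. No measurement here accounts for this result. Still open, as far as these compounds go, is how an amine or a carboxylic acid in place of the hydroxy would behave, and whether a longer chain carrying hydroxy would follow compound 3.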